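Triazole Cytotoxicity in Rat PC-12 Cells: Compound 4 Forecast

The source may hold more compounds than are shown below. What is called first, only, known or untested is meant among the compounds shown, and "the series" means these compounds.

The measured compounds:
compound 1 `CC(C)(C)c1ccc(-n2nc(-c3ccc(C(F)(F)F)cc3O)nc2-c2ccccc2O)cc1`, 77.8%
compound 2 `Oc1cc(C(F)(F)F)ccc1-c1nc(-c2ccccc2O)n(-c2ccccc2C(F)(F)F)n1`, 80%
compound 3 `COc1cccc(-n2nc(-c3ccc(C(F)(F)F)cc3O)nc2-c2ccccc2O)c1`, 96.8%

In a functional assay on PC-12 cells (Rattus norvegicus) for cytotoxicity, read by MTT assay, with stated times of 2 h and 24 h, tested at 5 uM (a lower number here means a weaker effect, a higher number a stronger effect of the compound at the concentration tested), compound 1 gives the lowest of the three numbers. Compound 2 gives 80%, and the step of a number 2.2 percentage points higher from compound 1 to compound 2 (within the scatter) lies within the scatter. Compound 3 gives 96.8%, and the step of a number 19 percentage points higher from compound 1 to compound 3 (beyond the scatter) is beyond the scatter, as is the step of a number 16.8 percentage points higher from compound 2 to compound 3 (beyond the scatter).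

Compound 4 `Oc1cc(C(F)(F)F)ccc1-c1nc(-c2ccccc2O)n(-c2ccc(F)cc2F)n1` has not yet been measured. It differs from compound 1 in one place: 2,4-difluorophenyl in place of 4-(tert-butyl)phenyl on an aromatic nitrogen.

Among the measured compounds shown here, two measured steps bear on this change, since both exchange the group on the same aromatic nitrogen. The exchange for a 2-(trifluoromethyl)phenyl group, a number 2.2 percentage points higher from compound 1 to compound 2 (within the scatter), left the number where it was. The exchange for a 3-methoxyphenyl group, a number 19 percentage points higher from compound 1 to compound 3 (beyond the scatter), raised it modestly. The 2,4-difluorophenyl group of compound 4 carries fluorine, as does the group in compound 2, so the closer guide is taken to be the step to compound 2, and compound 4 is expected to show a step of a number 4.2 percentage points higher from compound 1 to compound 4 (within the scatter), none beyond the scatter. The estimate for compound 4 is 82%, between 70% and 95%.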

Compound 4, a percentage reported as activity, at one concentration (the size of the read-out at that concentration, not a potency): 83.5%
Estimate against measurement, compound 4: 1.5 percentage points below; low and high end bracket the measured number.
By their numbers in this assay, from the lowest: compounds 1, 2 and 4 (each within the scatter of the next); then compound 3.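

Swapping the 4-(tert-butyl)phenyl group for 2,4-difluorophenyl on the aromatic nitrogen gives a number 5.7 percentage points higher from compound 1 to compound 4 (within the scatter) in this assay and, set against the 2-(trifluoromethyl)phenyl group, a number 3.5 percentage points higher from compound 2 to compound 4 (within the scatter) so the three groups in compounds 1, 2 and 4 are not separated by this read-out. The two fluorine-bearing groups therefore fall together here, but fluorine does not define that set, since the 4-(tert-butyl)phenyl group of compound 1 carries none and still sits with them, even though it has 10 heavy atoms against 8 for the group that enters. The 3-methoxyphenyl group now stands apart from three different groups rather than two, with a number 13.3 percentage points lower from compound 3 to compound 4 (beyond the scatter) making compound 3 the one clear outlier at this position.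

No supporting measurement bears on why the 3-methoxyphenyl group differs from the other three groups. Going by these compounds, it remains open whether a 4-methoxyphenyl group, an unsubstituted phenyl group, or a phenyl group carrying an amine or a carboxylic acid would read like compound 3 or like compounds 1, 2 and 4.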